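A few compounds are considered here, and "the series" means these few. Any claim that something is new, unique, unknown or untested is made for them only; others in the source may bear on it.

The two measured compounds share one core. Compound 1 `O=C(NO)c1coc(-c2ccccc2)n1` bears no substituent on the phenyl ring and in an assay on isolated protein for inhibition of protein deacetylase HDAC6 (Homo sapiens), read by fluorescence, with a stated time of 90 min (on this read-out lower numbers stand for stronger inhibition and higher numbers for weaker inhibition), compound 1 gives 270 nM. Going by the values given here, compound 2 `O=C(NO)c1coc(-c2ccc(Cl)cc2)n1` carries a chloro group, and in this assay compound 2 gives 81 nM, the lowest of the two numbers; the single measured step is a 3.3-fold lower number from compound 1 to compound 2 (0.52 log units; beyond the scatter).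

Compound 3 `O=C(NO)c1coc(-c2ccc(F)cc2)n1` is the next case. It differs from compound 2 by fluoro in place of chloro on an aromatic carbon. Among the compounds with values here, the one measured step, a 3.3-fold lower number from compound 1 to compound 2 (0.52 log units; beyond the scatter), shows that putting a halogen at this carbon instead of hydrogen lowers the number; it does not show how fluoro compares with chloro. Within the data shown here, with only that step to rely on, the expectation is that compound 3 will sit between the hydrogen case of compound 1 and the chloro case of compound 2, a change that is estimated as a 2.0-fold higher number from compound 2 to compound 3 (0.30 log units; within the scatter). The estimate for compound 3 in this assay is 160 nM, with an expected range from 70 nM to 350 nM.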

Compound 3, half-maximal inhibitory concentration: 110 nM
The estimate for compound 3 lay 1.5-fold (0.16 log units) above the measured number, and the stated range covers the measured number.
By their numbers in this assay, from the lowest: compounds 2 and 3 (each within the scatter of the next); then compound 1.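

In this assay, fluoro at this carbon also gives a number clearly lower than the hydrogen case (a 2.5-fold lower number from compound 1 to compound 3 (0.39 log units; beyond the scatter)), so the gain seen earlier with chloro is not confined to that one halogen. Exchanging chloro for fluoro (a 1.4-fold higher number from compound 2 to compound 3 (0.13 log units; within the scatter)) stays within the scatter, so compound 2 and compound 3 cannot be told apart on this read-out, and at this position either halogen serves about equally well. No measurement is available here to explain why a halogen at this carbon goes with a lower number than hydrogen.

The compounds shown span only hydrogen, fluoro and chloro at this carbon, so it remains open whether bromo, methyl, methoxy, an amine or a carboxylic acid there would give a number in the same range as the two halogens or would lose the gain. On these data alone, it also remains open whether a chloro or fluoro group on another carbon of the same aromatic ring would have a comparable effect.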